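Swapping the Benzyl Group: From Dichloro to Methoxy

A few compounds are considered here, and "the series" means these few. Any claim that something is new, unique, unknown or untested is made for them only; others in the source may bear on it.

Compound 1 `Nc1cc(N)c2nc(-c3ccccc3)c(NCc3ccc(Cl)c(Cl)c3)nc2c1`: in a functional assay on OVCAR-8 cells (Homo sapiens) for inhibition, read by sulforhodamine B assay, with a stated time of 48 h (a lower number here means that less compound is tolerated, a higher number that more compound is tolerated), compound 1 gives < 100000 nM, a limit of the assay rather than a number.
Compound 2 `CCOC(=O)[C@H](CCC(=O)O)NC(=O)c1ccc(Sc2nc3cc(N)cc(N)c3nc2-c2ccccc2)cc1`: compound 2 gives < 100000 nM, also a limit.
Compound 3 `CCOC(=O)[C@H](CCC(=O)O)NC(=O)c1ccc(Oc2nc3cc(N)cc(N)c3nc2-c2ccccc2)cc1`: compound 3 gives < 100000 nM, again a limit.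

Where compound 1 stands is therefore only loosely known: its value is a limit, and the two other compounds sit at the same limit, as the limit of < 100000 nM in this assay, at which 3 of the 3 values shown sit, records. For the measured compounds named here, no compound in this set has yet produced a measured number, so there is no measured step to lean on.

The unmeasured compound 4 `COc1ccc(CNc2nc3cc(N)cc(N)c3nc2-c2ccccc2)cc1` differs from compound 1 in one place: 4-methoxyphenyl in place of 3,4-dichlorophenyl on a saturated chain carbon bound to a nitrogen on an aromatic ring. With nothing but limits behind it, the step from compound 1 to compound 4 in this assay is expected to be none beyond the scatter, and the most likely outcome is that compound 4 again returns only a limit. On that basis the value of compound 4 is estimated at 40000 nM, with a range from 5000 nM to 100000 nM, a change of a step that the limit leaves unreadable from compound 1 to compound 4 expected against compound 1.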

Compound 4, concentration lethal to 50% of the cells: < 100000 nM
Compound 4 gave a limit, no number; the forecaster's own chance of this, stated with the estimate: 70%; the middle value lies beyond the limit too.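

Compound 1 and compound 4 both return only a limit in this assay, so no step can be read between them: the limit of < 100000 nM in this assay, at which 4 of the 4 values shown sit.

The compounds shown leave open whether 4-methoxyphenyl in place of 3,4-dichlorophenyl changes the result at all, and how the four compounds rank.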